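Amine substituent change from compound 2 to compound 3

The source may hold more compounds than are shown below. What is called first, only, known or untested is meant among the compounds shown, and "the series" means these compounds.

Compound 1 `COc1cccc(CNc2ccc(C(=O)N3CCC(N4CCCCC4)CC3)cc2Cl)c1` shows only the assay limit > 1000 nM in an assay on HEK293 cells for inhibition of Leucine-rich repeat serine/threonine-protein kinase 2 variant G2019S (Homo sapiens), with a stated time of 15 min; a higher number here means a weaker inhibitor, a lower number a stronger inhibitor.
Compound 2 `O=C(c1ccc(NCc2ccc([N+](=O)[O-])cc2)c(Cl)c1)N1CCC(N2CCCCC2)CC1` shows only the assay limit > 1000 nM in this assay.

Compound 2 stands at the limit of > 1000 nM in this assay, at which 2 of the 2 values shown sit. The step that the two limits leave unreadable from compound 1 to compound 2 therefore gives no readable size or direction. Compound 3 `Cn1cccc1CNc1ccc(C(=O)N2CCC(N3CCCCC3)CC2)cc1Cl` differs from compound 2 by 1-methyl-1H-pyrrol-2-yl in place of 4-nitrophenyl on a saturated chain carbon bound to a nitrogen on an aromatic ring. Among the compounds with values here, no measured step in this assay bears a number, so nothing in the set points to a gain or loss beyond the scatter; the measured values only say that weak inhibition is the state of the series so far. Compound 3 is expected to give 3000 nM, with a range from 700 nM to 20000 nM. The expected step that the limit leaves unreadable from compound 2 to compound 3 is estimated as essentially none, with a limit again the most likely outcome.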

Compound 3, half-maximal inhibitory concentration: > 1000 nM
Compound 3: no number, only a limit; the forecaster's own chance of this, stated with the estimate: 80%; the middle value lies beyond the limit too.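

No step among compound 1, compound 2 and compound 3 can be read, because each gives only an assay limit: the limit of > 1000 nM in this assay, at which 3 of the 3 values shown sit.

The compounds shown leave open how the 3-methoxyphenyl, 4-nitrophenyl and 1-methyl-1H-pyrrol-2-yl groups rank against one another.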